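A Bromine Added to Compound 2

A few compounds are considered here, and "the series" means these few. Any claim that something is new, unique, unknown or untested is made for them only; others in the source may bear on it.

Measured so far in an assay on isolated protein for inhibition of histone deacetylase 8 (Homo sapiens), read by fluorescence, with a stated time of 90 min; on this read-out lower numbers stand for stronger inhibition and higher numbers for weaker inhibition:
compound 1 `O=C(NO)c1coc(-c2ccc(F)cc2)n1` gives 43400 nM
compound 2 `O=C(NO)c1noc(-c2ccccc2)n1` gives 38500 nM

Compound 2 has the lower of the two numbers, but compound 1 sits within the scatter of it, so no order between them can be read. Compound 3 `O=C(NO)c1noc(-c2ccc(Br)cc2)n1` differs from compound 2 by bromo in place of hydrogen on an aromatic carbon. Going by the values given here, no measured pair shows this change, so its size is unknown; a modest step in this assay is expected, more likely toward stronger inhibition than away from it, and it may stay within the scatter. Compound 3 is estimated at 22000 nM, between 7000 nM and 70000 nM, meaning an expected step of a 1.8-fold lower number from compound 2 to compound 3 (0.24 log units; within the scatter).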

Compound 3, half-maximal inhibitory concentration: 20000 nM
Compound 3: middle estimate off by 1.1-fold (0.04 log units), on the high side; the measured number falls inside the stated range.
By their numbers in this assay, from the lowest: compounds 3, 2 and 1 (each within the scatter of the next, the first and the last beyond it).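

Bromo in place of hydrogen gives a 1.9-fold lower number from compound 2 to compound 3 (0.28 log units; within the scatter) in this assay and this is the first single change that can be read in this series. A bromine atom is therefore tolerated on this aromatic carbon, but with the step inside the scatter, no gain in inhibition can be claimed. Still open, going by these compounds, is whether a different group at this place, such as an amine or a carboxylic acid, would give a step beyond the scatter. No measurement offered here gives a reason for this result.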